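The source may hold more compounds than are shown below. What is called first, only, known or untested is meant among the compounds shown, and "the series" means these compounds.

Measured compounds in this series:
- compound 1, `CC(C)C(c1ncc[nH]1)c1ccc(-c2ccc3cccc(F)c3c2)[nH]c1=O`, 7.3 nM
- compound 2, `CC(C)C(c1nnc[nH]1)c1ccc(-c2ccc3cccc(F)c3c2)[nH]c1=O`, 12 nM
- compound 3, `CC(C)C(c1cnc(N)s1)c1ccc(-c2ccc3cccc(F)c3c2)[nH]c1=O`, 16 nM

All three were read in an assay on CHO cells for displacement of a labelled ligand from prostaglandin E2 receptor EP3 subtype (Homo sapiens), read by radioligand binding; a higher number here means a weaker inhibitor, a lower number a stronger inhibitor. Compound 2 gives the second highest of the three numbers. Its nearest neighbour is compound 3, reached by a 1.3-fold higher number from compound 2 to compound 3 (0.12 log units; within the scatter); its furthest is compound 1, the step being a 1.6-fold higher number from compound 1 to compound 2 (0.22 log units; within the scatter). Among the compounds with values here, the only step that goes beyond the scatter is a 2.2-fold higher number from compound 1 to compound 3 (0.34 log units; beyond the scatter), and even that is modest. The three heteroaryl groups on the saturated chain carbon therefore give numbers lying close together.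

Compound 4, `CC(C)C(Cc1nnc[nH]1)c1ccc(-c2ccc3cccc(F)c3c2)[nH]c1=O`, has not yet been measured. It differs from compound 2 in one place: (4H-1,2,4-triazol-3-yl)methyl in place of 4H-1,2,4-triazol-3-yl on a saturated chain carbon bound to an aromatic carbon and a saturated chain carbon. This is not a swap of one heteroaryl group for another but a lengthening of the link between the chain carbon and the same ring. Within the data shown here, none of the measured steps covers such a change; they all exchange one ring for another at the same attachment point, and all of them are small. Because the closest comparison is a 1.3-fold higher number from compound 2 to compound 3 (0.12 log units; within the scatter), which stays within the scatter, a small step is the most likely outcome, but the lack of any comparable change leaves the direction open. Compound 4 is expected to weaken somewhat, the estimated step being a 2.5-fold higher number from compound 2 to compound 4 (0.40 log units; beyond the scatter), with wide uncertainty. The estimate for compound 4 is 30 nM, range 8 nM to 120 nM.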

Compound 4, inhibition constant: 10 nM
The estimate for compound 4 lay 3.0-fold (0.48 log units) above the measured number; the measured number falls inside the stated range.
By their numbers in this assay, from the lowest: compounds 1, 4, 2 and 3 (each within the scatter of the next, the first and the last beyond it).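

In this assay, within the data shown here, (4H-1,2,4-triazol-3-yl)methyl in place of 4H-1,2,4-triazol-3-yl on the saturated chain carbon gives a 1.2-fold lower number from compound 2 to compound 4 (0.08 log units; within the scatter) as its step, so the read-out at this position stays within the scatter for a lengthened link as well as for the exchange of one ring for another, the only kind of change the earlier compounds covered. The same holds against the other two rings, with a 1.6-fold lower number from compound 3 to compound 4 (0.20 log units; within the scatter) as one step and a 1.4-fold higher number from compound 1 to compound 4 (0.14 log units; within the scatter) as the other, which places compound 4 among the compounds whose ring sits directly on the chain carbon, with no separation from any of them. No supporting data bear on why the added carbon leaves the number within the scatter of compound 2.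

The lengthened link is seen with the triazole alone, so the compounds shown leave open whether (1H-imidazol-2-yl)methyl or a longer chain, such as (4H-1,2,4-triazol-3-yl)ethyl, would stay in the same range. They also leave open whether any ring is needed on this chain carbon, which a simple amine or a carboxylic acid at the same place would test.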